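The source may hold more compounds than are shown below. What is called first, only, known or untested is meant among the compounds shown, and "the series" means these compounds.

Compound 1 `COc1ccc(-c2ccn(CCC(C)C)c(=O)c2C#N)cc1` gives 1150 nM in a functional assay on CHO cells for positive allosteric modulation of metabotropic glutamate receptor 2 (Homo sapiens), read by scintillation counting and GTPgammaS binding, with a stated time of 30 min; a lower number here means that less compound is needed, a higher number that more compound is needed for the effect.
Compound 2 `CC(C)CCn1ccc(-c2ccc(Oc3ccccc3)cc2)c(C#N)c1=O` gives 42 nM in this assay.

Among the measured compounds shown here, of these two numbers compound 2 has the lower one: the single step measured, a 27-fold lower number from compound 1 to compound 2 (1.44 log units; beyond the scatter), lies well beyond the scatter, and that step is the only one known here. Compound 3 `CC(C)CCn1ccc(-c2ccc(Oc3ccccn3)cc2)c(C#N)c1=O` differs from compound 2 by pyridin-2-yl in place of phenyl on an oxygen on an aromatic ring. For the measured compounds named here, no measured step changes the ring that hangs on this oxygen; the one known step swaps methyl for phenyl, a different kind of change, so it gives no direct guide to exchanging phenyl for pyridin-2-yl. Since both groups keep the same ring size and shape, and only one carbon becomes a nitrogen, the expected step of a 1.4-fold higher number from compound 2 to compound 3 (0.15 log units; within the scatter) is small and likely within the scatter. Compound 3 is therefore estimated at 60 nM, with a range from 20 nM to 200 nM.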

Compound 3, half-maximal effective concentration: 646 nM
For compound 3 the middle estimate is 11-fold (1.03 log units) below the measured one; measured number above the stated range.
By their numbers in this assay, from the lowest: compound 2; then compounds 3 and 1 (each within the scatter of the next).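

Changing a single ring carbon to nitrogen, with the ring size unchanged, gives a 15-fold higher number from compound 2 to compound 3 (1.19 log units; beyond the scatter), so this position on the oxygen is highly sensitive to the make-up of the ring. Compared with the methyl group of compound 1, the pyridin-2-yl group gives a 1.8-fold lower number from compound 1 to compound 3 (0.25 log units; within the scatter), which means that in this assay compound 3 cannot be told apart from compound 1. The large gain seen with phenyl therefore does not extend to every six-membered aromatic ring placed on this oxygen, and nothing measured here explains the difference.

The compounds shown leave open whether pyridin-3-yl or pyridin-4-yl on the same oxygen would behave like phenyl or like pyridin-2-yl. Also open, from the compounds shown here alone, is how a cyclohexyl group, which has no aromatic ring, would compare with either.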